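Swapping Chloro for Amino on Two Related Cores

A few compounds are considered here, and "the series" means these few. Any claim that something is new, unique, unknown or untested is made for them only; others in the source may bear on it.

Compound 1 `ClCc1ccccc1Cn1cnc2c(Cl)nc(Cl)nc21` and compound 2 `ClCc1cccc(Cn2cnc3c(Cl)nc(Cl)nc32)c1` are built from the same atoms joined differently; the difference between the two cores is not broken down here. In a functional assay on UO-31 cells (Homo sapiens) for cytotoxicity, read by sulforhodamine B assay, with a stated time of 48 h (on this read-out higher numbers stand for weaker inhibition of growth and lower numbers for stronger inhibition of growth), compound 1 gives 1510 nM and compound 2 gives 3090 nM. Compound 3 `Nc1nc(Cl)c2ncn(Cc3ccccc3CCl)c2n1` differs from compound 1 by a single change (amino in place of chloro on an aromatic carbon), and in this assay compound 3 gives 44700 nM, a step of a 30-fold higher number from compound 1 to compound 3 (1.47 log units; beyond the scatter). Compound 4 `Nc1nc(Cl)c2ncn(Cc3cccc(CCl)c3)c2n1` carries the same change, made on compound 2 instead (amino in place of chloro on an aromatic carbon). Going by the values given here, the step is expected to be about as large as the earlier one, a 26-fold higher number from compound 2 to compound 4 (1.41 log units; beyond the scatter), because a 30-fold higher number from compound 1 to compound 3 (1.47 log units; beyond the scatter) is the one measured example of this change and both place descriptions read the same. Compound 4 is therefore estimated at 80000 nM, most likely between 25000 nM and 200000 nM.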

Compound 4, concentration for total growth inhibition: 32400 nM
Compound 4: the middle estimate sits 2.5-fold (0.39 log units) above what was measured, and the stated range covers the measured number.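

In this assay, amino in place of chloro on an aromatic carbon again weakens growth inhibition, with a 10-fold higher number from compound 2 to compound 4 (1.02 log units; beyond the scatter) and thus the same direction on both cores. The size of the step does not carry over unchanged, however: the same change on two cores in this assay, a 30-fold higher number (1.47 log units; beyond the scatter) from compound 1 to compound 3 and a 10-fold higher number (1.02 log units; beyond the scatter) from compound 2 to compound 4, 2.8-fold (0.45 log units) apart, beyond the scatter of two such steps. Two cores show that the size can differ, but not what sets it or how large the step would be on a further core.

The compounds shown leave open how other groups on that aromatic carbon would compare with chloro and amino. A methoxy group or a dimethylamino group, for example, could show whether the large step is particular to amino.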